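Swapping the Aryl Amine on a Glutarimide Isoindolinedione

A few compounds are considered here, and "the series" means these few. Any claim that something is new, unique, unknown or untested is made for them only; others in the source may bear on it.

Measured compounds:
compound 1 `O=C1CCC(N2C(=O)c3cccc(Nc4ccccn4)c3C2=O)C(=O)N1` — 1%
compound 2 `Cc1ccc(Nc2ccc3c(c2)C(=O)N(C2CCC(=O)NC2=O)C3=O)cc1` — 5%
compound 3 `CCCc1ccc(Nc2ccc3c(c2)C(=O)N(C2CCC(=O)NC2=O)C3=O)cc1` — 10%

In an assay on FRT-Jurkat cells for inhibition of nuclear factor NF-kappa-B complex (Homo sapiens), read by flow cytometry, with a stated time of 24 h, tested at 10 uM (on this read-out higher numbers stand for more inhibition at the one concentration tested (going by the name of the read-out) and lower numbers for less inhibition), compound 1 gives 1%, the lowest of the three numbers, though compound 2 with 5% and compound 3 with 10% both lie within the scatter of it, so the three stand together rather than apart. Going by the values given here, the one measured step, a number 5 percentage points higher from compound 2 to compound 3 (within the scatter), does not part its two compounds either.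

Compound 4 `O=C1CCC(N2C(=O)c3cccc(Nc4ccc(O)cc4)c3C2=O)C(=O)N1` differs from compound 1 in a single place: 4-hydroxyphenyl in place of pyridin-2-yl on a nitrogen on an aromatic ring. Among the compounds with values here, no measured step swaps one aromatic ring for another on that nitrogen; the only step recorded changes a chain on a ring carbon far from this position, and it stayed within the scatter. All three measured values are low, and nothing among them points to a larger number for a change of this kind.

The account therefore expects compound 4 to stay near the others, with an estimated step of a number 4 percentage points higher from compound 1 to compound 4 (within the scatter) from compound 1 in this assay. The estimate for compound 4 is 5%, with a range from -5% to 15%.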

Compound 4, a percentage reported as inhibition, at one concentration (the size of the read-out at that concentration, not a potency): 4%
Compound 4: the middle estimate sits 1 percentage points above what was measured, and the stated range covers the measured number.
By their numbers in this assay, from the lowest: compounds 1, 4, 2 and 3 (each within the scatter of the next).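

In this assay, going by these compounds alone, the exchange of pyridin-2-yl for 4-hydroxyphenyl on a nitrogen on an aromatic ring reads as a number 3 percentage points higher from compound 1 to compound 4 (within the scatter) and is the first step recorded at this place. It replaces a six-membered aromatic ring with one hetero atom by a ring of carbon only and brings in a hydrogen-bond donor, yet the two compounds are not parted by this read-out. The earlier compounds shown here offered no step at this nitrogen, and compound 4 now shows that this particular exchange of one aromatic ring for another leaves compound 1 and compound 4 together within the scatter.

Nothing available explains this outcome or bears on it directly.

Still open, on these data alone, is whether a ring carrying an amine or a carboxylic acid in place of the hydroxy group, or a longer chain on this nitrogen in place of an aromatic ring, would give a number clear of the scatter. Also open is whether any group at this place can part a compound from the others at all, as every step shown so far lies within the scatter.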